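This account rests on a few compounds, and the source may have more. Where it says the series, first, only, none or still open, it means among the compounds named here.

Working notes on the thiosemicarbazone series sharing the core of compound 1 `COc1ccccc1NC(=S)N/N=C/c1ccc2ccccc2n1`. In a functional assay on HL-60 cells (Homo sapiens) for antiproliferative activity, read by sulforhodamine B assay, with a stated time of 72 h (a higher number here means a weaker inhibitor, a lower number a stronger inhibitor), compound 1 gives 91700 nM, the highest of the two numbers available; the nearest, compound 3 `S=C(N/N=C/c1ccc2ccccc2n1)Nc1ccccc1`, gives 9130 nM. Compound 2 `S=C(N/N=C/c1ccc2ccccc2n1)Nc1ccccc1Br` reaches only the limit (the limit of > 100000 nM in this assay, at which 1 of the 3 values shown sits), so compound 2 gives > 100000 nM as a limit and no number.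

Measured steps: a 10-fold lower number from compound 1 to compound 3 (1.00 log units; beyond the scatter); an at least 10-fold lower number from compound 2 to compound 3 (1.03 log units; beyond the scatter); an at least 1.0-fold higher number from compound 1 to compound 2 (0.03 log units; that floor lies within the scatter). Within the data shown here, both steps that remove a substituent from the phenyl ring lower the number clearly, so the 2-methoxyphenyl of compound 1 appears to weigh against activity within this set; no measured pair addresses the change of position itself.

Compound 4 `COc1ccc(NC(=S)N/N=C/c2ccc3ccccc3n2)cc1`, not yet measured, differs from compound 1 by 4-methoxyphenyl in place of 2-methoxyphenyl on an amide-type nitrogen. Among the measured compounds shown here, since the change keeps the methoxy but relocates it, and the only nearby guidance is the step from compound 1 to compound 3 a 10-fold lower number from compound 1 to compound 3 (1.00 log units; beyond the scatter), a lower number than compound 1 is expected, though short of compound 3. For compound 4 the estimate is 30000 nM, with a range of 8000 nM to 100000 nM, meaning an expected step of a 3.1-fold lower number from compound 1 to compound 4 (0.49 log units; beyond the scatter).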

Compound 4, half-maximal inhibitory concentration: 43800 nM
For compound 4 the middle estimate is 1.5-fold (0.16 log units) below the measured one; the range from low to high includes it.
By their numbers in this assay, from the lowest: compound 3; then compound 4; then compound 1. At a limit, above all of these: compound 2.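

Relocating the methoxy alone moves the result in this assay, with a 2.1-fold lower number from compound 1 to compound 4 (0.32 log units; beyond the scatter) as the step, so the place of this group on the phenyl ring matters, which no earlier pair could show. The relocated group still does not match hydrogen, as a 4.8-fold higher number from compound 3 to compound 4 (0.68 log units; beyond the scatter) shows, so in this pair and in the step from compound 1 to compound 3 the methoxy goes with a higher number at either place. The step of an at least 2.2-fold lower number from compound 2 to compound 4 (0.35 log units; beyond the scatter) gives only a floor, and compound 2 stands at a limit and not a number: the limit of > 100000 nM in this assay, at which 1 of the 4 values shown sits.

From the compounds shown here alone, whether relocating the bromo of compound 2 would also lower the number remains open. So does how an amine or a carboxylic acid on the phenyl ring would compare with hydrogen and methoxy.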